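Amide substituent on the shared core: tert-butyl to imidazolyl

This account rests on a few compounds, and the source may have more. Where it says the series, first, only, none or still open, it means among the compounds named here.

Measured so far:
compound 1, `CC(C)[C@H](C(=O)NC(C)(C)C)c1ccc(Cl)cc1`: > 100000 nM
compound 2, `CC(C)C(C(=O)Nc1ncccn1)c1ccc(Cl)cc1`: 53000 nM
compound 3, `CC(C)[C@H](C(=O)Nc1nnc(C(F)(F)F)s1)c1ccc(Cl)cc1`: 1900 nM

Compound 1 carries a tert-butyl group on the amide nitrogen of the shared core. In a functional assay on CHO cells for agonist activity at Free fatty acid receptor 2 (Homo sapiens), read by cAMP accumulation (on this read-out lower numbers stand for stronger inhibition and higher numbers for weaker inhibition), compound 1 reaches only a limit, > 100000 nM, and not a number. It stands at the limit of > 100000 nM in this assay, at which 1 of the 3 values shown sits; no figure of its own is therefore known. The other two compounds replace the alkyl group with a heteroaromatic ring on the same nitrogen: compound 2 gives 53000 nM in this assay, and compound 3 gives 1900 nM. Among the measured compounds shown here, no two of the three compounds differ in one place only, so no single step has been measured.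

Compound 4, `CC(C)[C@H](C(=O)Nc1ncc[nH]1)c1ccc(Cl)cc1`, differs from compound 1 by 1H-imidazol-2-yl in place of tert-butyl on an amide-type nitrogen. It thus joins the heteroaryl amides of compound 2 and compound 3 rather than the alkyl amide of compound 1. Since compound 1 sits at a limit, the step cannot be given a size from the data; the expectation is for a gain beyond the scatter, that is, a move towards the values of compound 2 and compound 3. The estimated step from compound 1 to compound 4 is an at least 8.3-fold lower number from compound 1 to compound 4 (0.92 log units; beyond the scatter). Compound 4 is expected to give about 12000 nM in this assay, within 2500 nM to 60000 nM.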

Compound 4, half-maximal inhibitory concentration: 20000 nM
Beside the measured number, compound 4's estimate is 1.7-fold (0.22 log units) below it; the range from low to high includes it.
By their numbers in this assay, from the lowest: compound 3; then compound 4; then compound 2. At a limit, above all of these: compound 1.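

In this assay, among the compounds shown here, 1H-imidazol-2-yl in place of tert-butyl on the amide-type nitrogen gives the first single-place step in this set: an at least 5.0-fold lower number from compound 1 to compound 4 (0.69 log units; beyond the scatter). On these data alone, this size is only a lower bound, and the true gap is unknown, since the value for compound 1 is a limit and not a number: the limit of > 100000 nM in this assay, at which 1 of the 4 values shown sits. The step shows that the potency read-out at this position responds to the change of substituent, but the change brings in one five-membered aromatic ring, 1 hydrogen-bond donor and 1 hydrogen-bond acceptor together, and a single step does not separate these features.

Still open is which of these features accounts for the lower number, a question that an imidazol-2-yl ring bearing a methyl group on its ring nitrogen, or a phenyl ring in the same place, could help to answer. Also open, as far as these compounds go, is whether the trend extends to substituents of another kind on this nitrogen, such as a chain ending in a carboxylic acid or an amine.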